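Swapping a Bicyclic Amine for Piperidine on the Core

The compounds below may be only part of what the source reports. "The series", "measured", "known", "first", "only" and "open" are said of these compounds alone.

Measured compounds:
- compound 1 `CC(=O)Nc1cc(-c2cnc(N(C)C(=O)c3c(F)cccc3Cl)c(N3CC4CC4C3)c2)n(C(C)C)n1` — 48 ug/mL
- compound 2 `CC(=O)Nc1cc(-c2ccc(N(C)C(=O)c3c(F)cccc3Cl)c(N3CCCCC3)c2)n(C(C)C)n1` — 1.3 ug/mL

In a physicochemical assay for solubility, measured as kinetic solubility (a lower number here means a less soluble compound, a higher number a more soluble compound), compound 1 gives 48 ug/mL, the higher of the two numbers recorded. Among the measured compounds shown here, compound 2 gives 1.3 ug/mL in this assay, a gap well beyond the scatter; compound 2 differs from compound 1 in more than one place, so no single step is assigned to that gap.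

Compound 3 `CC(=O)Nc1cc(-c2cnc(N(C)C(=O)c3c(F)cccc3Cl)c(N3CCCCC3)c2)n(C(C)C)n1` has not yet been measured. It keeps the core of compound 1 and alters one group: a group of 6 heavy atoms (5 carbon, 1 nitrogen; one six-membered non-aromatic ring with 1 hetero atom) in place of a group of 6 heavy atoms (5 carbon, 1 nitrogen; one three-membered non-aromatic ring of carbon only, one five-membered non-aromatic ring with 1 hetero atom), on an aromatic carbon. The incoming piperidin-1-yl group is the same amine carried by compound 2, while the ring bearing the nitrogen remains that of compound 1.

For the measured compounds named here, with no directly matched step in hand, the outcome is drawn from the two recorded values alone. Compound 3 is expected to fall below compound 1 in this assay, by a moderate step of a 3.2-fold lower number from compound 1 to compound 3 (0.51 log units; beyond the scatter), since compound 2 with the same amine gives 1.3 ug/mL. Compound 3 is estimated at 15 ug/mL, within a range of 4 ug/mL to 50 ug/mL.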

Compound 3, solubility: 37.4 ug/mL
Compound 3: the middle estimate sits 2.5-fold (0.40 log units) below what was measured; the range from low to high includes it.
By their numbers in this assay, from the lowest: compound 2; then compounds 3 and 1 (each within the scatter of the next).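

In this assay, piperidin-1-yl in place of the bicyclic amine, on the aromatic carbon ortho to the ((2-chloro-6-fluorophenyl)carbonyl)(methyl)amino group, gives a 1.3-fold lower number from compound 1 to compound 3 (0.11 log units; within the scatter), so on the core of compound 1 this position does not separate these two amines. The earlier pair could not show this, since compound 1 and compound 2 differ in more than one place, but compound 3 carries the amine of compound 2 and still stands with compound 1 rather than with compound 2. Compound 2 gives 1.3 ug/mL and compound 3 gives 37.4 ug/mL, a gap that now lies across a single difference, the ring nitrogen of compound 3, though nothing at hand accounts for the numbers.

The compounds shown leave open whether this tolerance extends to amines of another kind at the same position, such as morpholine, piperazine or the smaller azetidine. They also leave open whether the bicyclic amine of compound 1 would give a different number on the core of compound 2, which lacks that ring nitrogen.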